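Notes on the step from compound 2 to compound 3

The source may report more compounds than this note shows. Statements on the series, on what has been measured and on what is new or still open speak of the compounds shown alone.

Values in a functional assay (strain AB) with Danio rerio as the target, read by microscopy, with a stated time of 1 h; on this read-out lower numbers stand for an effect already at smaller amounts and higher numbers for an effect only at larger amounts of compound:
- compound 1 `CC(C)(C)OC(=O)CCCC[N+]1(C)CCc2c(sc(NC(=O)Nc3ccc(Cl)cc3)c2C(N)=O)C1`: 140 nM
- compound 2 `C[N+]1(CC2CCCCC2)CCc2c(sc(NC(=O)Nc3ccc(Cl)cc3)c2C(N)=O)C1`: 100 nM

Compound 2, at 100 nM, cannot be separated from compound 1, at 140 nM; the two numbers lie within the scatter of each other. Compound 3 `CC(C)(C)OC(=O)CCCCC[N+]1(C)CCc2c(sc(NC(=O)Nc3ccc(Cl)cc3)c2C(N)=O)C1` has not yet been measured. It carries 4-(tert-butoxycarbonyl)butyl in place of cyclohexyl on a saturated chain carbon bound to an amine nitrogen in a ring.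

Among the compounds with values here, only one measured step bears on this change. It exchanges 3-(tert-butoxycarbonyl)propyl for cyclohexyl at the same place and amounts to a 1.4-fold lower number from compound 1 to compound 2 (0.15 log units; within the scatter). Within the data shown here, the group in compound 3 is the butyl counterpart of the propyl group in compound 1, and no measured step covers that difference in chain, so the estimate carries a wide range. No step beyond the scatter is therefore expected in this assay. The expected change is a 1.3-fold higher number from compound 2 to compound 3 (0.11 log units; within the scatter). Compound 3 is estimated at 130 nM, with an expected range of 50 nM to 340 nM.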

Compound 3, half-maximal effective concentration: 110 nM
Compound 3: the middle estimate sits 1.2-fold (0.07 log units) above what was measured; measured number inside the range.
By their numbers in this assay, from the lowest: compounds 2, 3 and 1 (each within the scatter of the next).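

In this assay, the open-chain 4-(tert-butoxycarbonyl)butyl group and the ring-bearing cyclohexyl group cannot be told apart on a saturated chain carbon bound to an amine nitrogen in a ring: the exchange gives a 1.1-fold higher number from compound 2 to compound 3 (0.04 log units; within the scatter) and stays inside the usual variation between repeats. Within the data shown here, the butyl chain against the propyl chain, a difference no earlier step covered, gives a 1.3-fold lower number from compound 1 to compound 3 (0.10 log units; within the scatter) and is likewise unresolved, so compound 1, compound 2 and compound 3 together show that this place accepts a ring of carbon only and two tert-butoxycarbonyl chains of different length with no separable change in the read-out. No measurement at hand offers an explanation for this flat result.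

Still open, going by these compounds, is whether a free carboxylic acid in place of the tert-butoxycarbonyl group, or a primary amine at the chain end, would stay in the same range in this assay. Also open, on these data alone, is whether a much longer chain, or a short alkyl group such as ethyl, would produce a step beyond the scatter at this place.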